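Swapping the Side Ring of a Shared Core

A few compounds are considered here, and "the series" means these few. Any claim that something is new, unique, unknown or untested is made for them only; others in the source may bear on it.

The measured compounds:
Compound 1, `N#Cc1cc(-c2nc(C(c3ccc(F)cc3)c3ccc(F)cc3)sc2CC(=O)O)ccc1F`, gives 520 nM in an in vitro functional assay on HEK285-7 cells for antagonist activity at prostaglandin D2 receptor 2 (Homo sapiens), read by BRET and beta-arrestin recruitment; a lower number here means a stronger inhibitor, a higher number a weaker inhibitor.
Compound 2, `NS(=O)(=O)c1ccc(-c2nc(C(c3ccc(F)cc3)c3ccc(F)cc3)sc2CC(=O)O)cc1`, reaches only a limit of the assay, > 100000 nM, rather than a number (the limit of > 100000 nM in this assay, at which 1 of the 3 values shown sits).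
Compound 3, `O=C(O)Cc1sc(C(c2ccc(F)cc2)c2ccc(F)cc2)nc1-c1ccoc1`, gives 130 nM.

Among the two numbers that are actual values, compound 3 stands lowest, with compound 1 nearest at a 4.0-fold lower number from compound 1 to compound 3 (0.60 log units; beyond the scatter). The unmeasured compound 4, `O=C(O)Cc1sc(C(c2ccc(F)cc2)c2ccc(F)cc2)nc1-c1cc(F)nc(F)c1`, differs from compound 3 in one place: 2,6-difluoropyridin-4-yl in place of furan-3-yl on an aromatic carbon. Two measured steps change the same side ring. From compound 1 to compound 3 the number fell, a 4.0-fold lower number from compound 1 to compound 3 (0.60 log units; beyond the scatter), a modest step; from compound 1 to compound 2 it rose sharply, an at least 190-fold higher number from compound 1 to compound 2 (2.28 log units; beyond the scatter), and from compound 2 to compound 3 it fell again, an at least 760-fold lower number from compound 2 to compound 3 (2.88 log units; beyond the scatter). The incoming 2,6-difluoropyridin-4-yl is a six-membered aromatic ring, as is the 3-cyano-4-fluorophenyl of compound 1, so a modest rise back toward compound 1 is the expected outcome, though a large loss cannot be ruled out. Compound 4 is therefore expected near 350 nM, within 100 nM to 1500 nM, an expected step of a 2.7-fold higher number from compound 3 to compound 4 (0.43 log units; beyond the scatter).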

Compound 4, half-maximal inhibitory concentration: 110 nM
Estimate against measurement, compound 4: 3.2-fold (0.50 log units) above; low and high end bracket the measured number.
By their numbers in this assay, from the lowest: compounds 4 and 3 (each within the scatter of the next); then compound 1. At a limit, above all of these: compound 2.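

The five-membered furan-3-yl and the six-membered 2,6-difluoropyridin-4-yl cannot be told apart in this assay, a 1.2-fold lower number from compound 3 to compound 4 (0.07 log units; within the scatter), so among these compounds ring size alone does not set the number at this position. What the six-membered ring carries does matter: the 2,6-difluoropyridin-4-yl gives a 4.7-fold lower number from compound 1 to compound 4 (0.67 log units; beyond the scatter) against the 3-cyano-4-fluorophenyl, and an at least 900-fold lower number from compound 2 to compound 4 (2.95 log units; beyond the scatter) against the 4-sulfamoylphenyl. That last comparison rests on a limit and not on a number for compound 2: the limit of > 100000 nM in this assay, at which 1 of the 4 values shown sits.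

The compounds shown leave open how much of the 2,6-difluoropyridin-4-yl result comes from its ring nitrogen and how much from its fluorines, a question that a plain phenyl or an unsubstituted pyridin-4-yl would help to settle. Also open, on these data alone, is how a six-membered ring bearing an amine or a methoxy group would behave here.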